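An aryl ester returns to the cyclohexyl core

The source may report more compounds than this note shows. Statements on the series, on what has been measured and on what is new or still open speak of the compounds shown alone.

Three esters of a shared core have been measured in an ADME assay on WI-38 cells (Homo sapiens) for inhibition, read by MTT assay, with a stated time of 72 h; a lower number here means a stronger inhibitor, a higher number a weaker inhibitor. Compound 1 `O=C(OC1(C(=O)Nc2ccc([N+](=O)[O-])cc2)CCCCC1)c1ccc(C(F)(F)F)cc1` gives 185 nM. Compound 2 `O=COC1(C(=O)Nc2ccc([N+](=O)[O-])cc2)CCCCC1` gives 46.3 nM, and compound 3 `CCC(=O)OC1(C(=O)Nc2ccc([N+](=O)[O-])cc2)CCCCC1` gives 44.6 nM. Compound 3 holds the lowest of the three numbers, but its nearest neighbour, compound 2, sits within the scatter (a 1.0-fold lower number from compound 2 to compound 3 (0.02 log units; within the scatter)), so those two cannot be ordered; compound 1 lies clearly further away (a 4.1-fold lower number from compound 1 to compound 3 (0.62 log units; beyond the scatter)).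

Compound 4 `CC(=O)Oc1ccccc1C(=O)OC1(C(=O)Nc2ccc([N+](=O)[O-])cc2)CCCCC1` differs from compound 3 in one place: 2-acetoxyphenyl in place of ethyl on a carbonyl carbon. Among the measured compounds shown here, two measured steps bear on this change, both of them replacing an aromatic ring on this carbonyl carbon with a small group: a 4.0-fold lower number from compound 1 to compound 2 (0.60 log units; beyond the scatter) and a 4.1-fold lower number from compound 1 to compound 3 (0.62 log units; beyond the scatter). Compound 4 runs the other way, restoring an aromatic ring on the carbonyl carbon, although a different one from that of compound 1. A modestly higher number in this assay is therefore expected, a 2.9-fold higher number from compound 3 to compound 4 (0.46 log units; beyond the scatter). The estimate for compound 4 in this assay is 130 nM, with a range from 45 nM to 400 nM.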

Compound 4, half-maximal inhibitory concentration: 48.4 nM
Beside the measured number, compound 4's estimate is 2.7-fold (0.43 log units) above it; measured number inside the range.
By their numbers in this assay, from the lowest: compounds 3, 2 and 4 (each within the scatter of the next); then compound 1.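

In this assay, an aromatic ring on this carbonyl carbon proves not to be enough on its own to separate a compound from the small esters: 2-acetoxyphenyl reads level with ethyl, a 1.1-fold higher number from compound 3 to compound 4 (0.04 log units; within the scatter), and level with hydrogen, a 1.0-fold higher number from compound 2 to compound 4 (0.02 log units; within the scatter). The two aromatic groups also part company, with a 3.8-fold lower number from compound 1 to compound 4 (0.58 log units; beyond the scatter), so among the four compounds only compound 1, with its 4-(trifluoromethyl)phenyl, stands apart, and the earlier contrast between aromatic and small groups turns out to belong to that group rather than to aromatic rings in general. Nothing available accounts for this difference between the two aromatic groups.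

The compounds shown leave open which feature of 4-(trifluoromethyl)phenyl goes with the higher number, since an unsubstituted phenyl ring on this carbonyl carbon does not appear among them. They also leave open how a longer chain than ethyl, an amine or a carboxylic acid at this place would read in this assay, and so how far the level shared by compounds 2, 3 and 4 extends.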